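From compound 1 to compound 3: losing tert-butoxycarbonyl

The compounds below may be only part of what the source reports. "The series", "measured", "known", "first", "only" and "open" are said of these compounds alone.

In a functional assay on MCF7 cells (Homo sapiens) for cytotoxicity, read by MTT assay, with a stated time of 72 h (a lower number here means a stronger inhibitor, a higher number a weaker inhibitor), compound 1 (`CC(C)(C)OC(=O)N1CCN(c2c(C(=O)NCc3ccc(F)cc3)nc(Br)c3cccnc23)CC1`) gives > 10000 nM as its result, which is a limit of the assay and not a number. Compound 2 (`N[C@H]1CC[C@H](NC(=O)c2nc(Br)c3cccnc3c2NCc2ccc(F)cc2)CC1`) has the entry "not determined" (no result reported) and so offers no comparison. Compound 3 (`O=C(NCc1ccc(F)cc1)c1nc(Br)c2cccnc2c1N1CCNCC1`) has hydrogen in place of tert-butoxycarbonyl on an amine nitrogen in a ring. Going by the values given here, no measured step gauges this change, so the expected move in this assay is only a modest strengthening (an at least 1.6-fold lower number from compound 1 to compound 3 (0.22 log units; that floor lies within the scatter)). Compound 3 is estimated at 6000 nM (range 1500 nM to 20000 nM) and may yet return only a limit.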

Compound 3, half-maximal inhibitory concentration: 7000 nM
Beside the measured number, compound 3's estimate is 1.2-fold (0.07 log units) below it, within the range that was stated.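

In this assay compound 3 gives 7000 nM as an exact number, the only one among the compounds shown, so this ring nitrogen with hydrogen on it can be placed on the scale. Compound 1 gives > 10000 nM as its result, which is a limit and not a number. As far as these compounds go, the change can be read only as an at least 1.4-fold lower number from compound 1 to compound 3 (0.15 log units; that floor lies within the scatter) and its true size stays unknown because compound 1 has no exact value: the limit of > 10000 nM in this assay, at which 1 of the 3 values shown sits.

Open, from the compounds shown here alone, is how a small group on this same ring nitrogen, such as methyl or acetyl, would compare with hydrogen. Whether any such group would give a lower number than compound 3 also remains unanswered.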